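This account rests on a few compounds, and the source may have more. Where it says the series, first, only, none or still open, it means among the compounds named here.

The series shares one core, carried through compound 1 `O=C(Nc1ccc(-n2ccc3c(NC(=O)c4ccccc4)nccc32)cc1)Nc1cccc(Cl)c1Cl`, compound 2 `O=C(Nc1ccc(-n2ccc3c(NC(=O)c4ccccc4)nccc32)cc1)Nc1cccc(C(F)(F)F)c1` and compound 3 `O=C(Nc1ccc(-n2ccc3c(NC(=O)c4ccccc4)nccc32)cc1)c1cccc(C(F)(F)F)c1`. In a functional assay on A-375 cells (Homo sapiens) for antiproliferative activity, read by MTT assay, with a stated time of 48 h, in the presence of a further agent that is not named here (on this read-out lower numbers stand for stronger inhibition and higher numbers for weaker inhibition), compound 1 gives > 10000 nM, which is a limit of the assay and not a number. Compound 2 gives 7000 nM. Compound 3 gives 100 nM, the lowest number seen here, with the step of a 70-fold lower number from compound 2 to compound 3 (1.85 log units; beyond the scatter) lying beyond the scatter. Compound 4 `O=C(Nc1ccc(-n2ccc3c(NC(=O)c4ccccc4)nccc32)cc1)c1ccc(Cl)c(C(F)(F)F)c1` differs from compound 3 by chloro in place of hydrogen on an aromatic carbon. Among the compounds with values here, no measured step changes a single substituent on an aryl amide; the step of an at least 1.4-fold lower number from compound 1 to compound 2 (0.15 log units; that floor lies within the scatter) alters the aryl of a urea and starts from a limit, so it carries little weight. The expected step is a 1.3-fold lower number from compound 3 to compound 4 (0.10 log units; within the scatter), within the scatter. Compound 4 is estimated at 80 nM, with a range of 30 nM to 250 nM.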

Compound 4, half-maximal inhibitory concentration: 16.4 nM
For compound 4 the middle estimate is 4.9-fold (0.69 log units) above the measured one, and the stated range ends above it.
By their numbers in this assay, from the lowest: compound 4; then compound 3; then compound 2. At a limit, above all of these: compound 1.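

Chloro ortho to a trifluoromethyl group on the aryl amide gives a 6.1-fold lower number from compound 3 to compound 4 (0.79 log units; beyond the scatter) in this assay and is the first single-substituent step on this ring to lie beyond the scatter. Measured against the urea of compound 2, the change to 4-chloro-3-(trifluoromethyl)phenyl widens to a 430-fold lower number from compound 2 to compound 4 (2.63 log units; beyond the scatter) on this read-out. The step of an at least 600-fold lower number from compound 1 to compound 4 (2.78 log units; beyond the scatter) is only a floor, set by a limit of the assay: the limit of > 10000 nM in this assay, at which 1 of the 4 values shown sits.

As far as these compounds go, whether this gain is specific to chloro stays open, as does the outcome with a methoxy or dimethylamino group at this position. Also open, from the compounds shown here alone, is whether chloro keeps the step without the trifluoromethyl group.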